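Removing the ring methyl from compound 3

The compounds below may be only part of what the source reports. "The series", "measured", "known", "first", "only" and "open" are said of these compounds alone.

Measured so far:
- compound 1 `Cc1cccc(CN(C)C(=O)c2cc(Cl)c(O)cc2O)c1`: 11300 nM
- compound 2 `O=C(NCc1ccccc1)c1cc(Cl)c(O)cc1O`: "not active" (no number reported)
- compound 3 `Cc1ccc(CN(C)C(=O)c2cc(Cl)c(O)cc2O)cc1`: 7200 nM

All three compounds were tested in a functional assay on SK-BR-3 cells (Homo sapiens) for antiproliferative activity, with a stated time of 72 h; on this read-out lower numbers stand for stronger inhibition of growth and higher numbers for weaker inhibition of growth. Only two of them gave a number. Compound 3 at 7200 nM lies within the scatter of compound 1 at 11300 nM, so the two cannot be ranked. Compound 2 was reported without a number, so no step size can be read from it.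

The next compound to consider is compound 4 `CN(Cc1ccccc1)C(=O)c1cc(Cl)c(O)cc1O`. It carries hydrogen in place of methyl on an aromatic carbon of compound 3, that is, phenyl instead of 4-methylphenyl (hydrogen in place of methyl on an aromatic carbon).

Within the data shown here, only one measured step bears on this change. Going a 1.6-fold lower number from compound 1 to compound 3 (0.20 log units; within the scatter), the methyl group changes its place on the ring, and the size of that step stays within the scatter. Among the measured compounds shown here, no measured step removes the methyl group altogether, so this is indirect evidence only. It suggests that the methyl group's place on the ring has little influence on the number in this assay, and it gives no firm direction. A step beyond the scatter is therefore not expected, and the expected step is a 1.3-fold higher number from compound 3 to compound 4 (0.10 log units; within the scatter).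

For compound 4 the estimated value is 9000 nM, with an expected range from 3500 nM to 25000 nM.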

Compound 4, concentration for 50% growth inhibition: 18300 nM
Compound 4: the middle estimate sits 2.0-fold (0.31 log units) below what was measured, and the stated range covers the measured number.
By their numbers in this assay, from the lowest: compounds 3, 1 and 4 (each within the scatter of the next, the first and the last beyond it).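

In this assay, among these compounds, the ring methyl now makes a readable difference for the first time: replacing it with hydrogen on the aromatic carbon para to a large group gives a 2.5-fold higher number from compound 3 to compound 4 (0.41 log units; beyond the scatter) and so weakens growth inhibition modestly. Removing the methyl from its other place on the ring, in compound 1, gives a 1.6-fold higher number from compound 1 to compound 4 (0.21 log units; within the scatter) and cannot be told apart from ordinary scatter, so the methyl shows a clear effect only in the 4-methylphenyl form, even though compound 1 and compound 3 themselves cannot be ranked. Nothing measured here gives a reason for this difference.

The compounds shown leave open whether another group at that same ring carbon, such as a chlorine, a methoxy group, an amine or a longer chain like ethyl, would match or pass the methyl. Compound 2 carries the amide hydrogen where compound 4 has a methyl on the nitrogen, but it has no number, so that step cannot be read and the role of the nitrogen methyl stays unsettled.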